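A few compounds are considered here, and "the series" means these few. Any claim that something is new, unique, unknown or untested is made for them only; others in the source may bear on it.

Measured so far:
- compound 1, `COc1ccc(-c2cc(/C=C/C(=O)c3ccc(N)cc3)[nH]n2)cc1`: 2420 nM
- compound 2, `COc1cc(-c2cc(/C=C/C(=O)c3ccc(N)cc3)[nH]n2)cc(OC)c1OC`: 2210 nM
- compound 3, `COc1ccc(C(=O)/C=C/c2cc(-c3cc(OC)c(OC)c(OC)c3)n[nH]2)cc1`: 1510 nM

In a functional assay on PC-3 cells (Homo sapiens) for inhibition, read by sulforhodamine B assay, with a stated time of 48 h (a higher number here means a weaker inhibitor of growth, a lower number a stronger inhibitor of growth), compound 2 gives 2210 nM, the second highest of the three numbers; compound 1 sits nearest and compound 3 furthest, and both gaps are within the scatter, so the three compounds are not separated by this assay.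

Compound 4, `COc1ccc(-c2cc(/C=C/C(=O)c3ccc(N)cc3)[nH]n2)cc1OC`, is not yet measured. It differs from compound 2 by hydrogen in place of methoxy on an aromatic carbon. Among the compounds with values here, no measured step touches the same place. Within the data shown here, the one measured step, a 1.5-fold lower number from compound 2 to compound 3 (0.17 log units; within the scatter), concerns a different position and lies within the scatter. Compound 1 and compound 2, which differ in the number of methoxy groups on that ring, give values within the scatter of each other; compound 4 carries a count of methoxy groups between the two.

Compound 4 is therefore expected to give 2300 nM in this assay, with a range of 1300 nM to 4200 nM. The expected step is a 1.0-fold higher number from compound 2 to compound 4 (0.02 log units; within the scatter), nothing beyond the scatter.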

Compound 4, concentration for 50% growth inhibition: 3710 nM
Beside the measured number, compound 4's estimate is 1.6-fold (0.21 log units) below it, and the stated range covers the measured number.
By their numbers in this assay, from the lowest: compounds 3, 2, 1 and 4 (each within the scatter of the next, the first and the last beyond it).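

In this assay, within the data shown here, hydrogen in place of methoxy on this aromatic carbon, ortho to a methoxy group and meta to a large group, gives a 1.7-fold higher number from compound 2 to compound 4 (0.22 log units; within the scatter), the first direct reading of this position. Methoxy in place of hydrogen on an aromatic carbon of the same ring gives a 1.5-fold higher number from compound 1 to compound 4 (0.19 log units; within the scatter), so with both steps within the scatter, compounds 1, 2 and 4 show no trend with the number of methoxy groups on that ring. Nothing at hand offers an explanation for these readings.

From the compounds shown here alone, whether a hydroxy group, a fluorine atom or an ethoxy group on this aromatic carbon would give a step beyond the scatter remains open. Also open, going by these compounds, is whether hydrogen in place of methoxy here reads the same with methoxy in place of the amino group, as in compound 3.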